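The source may hold more compounds than are shown below. What is called first, only, known or untested is meant among the compounds shown, and "the series" means these compounds.

Measured so far:
- compound 1 `O=C(NCc1ccc(Cl)cc1)c1ccc([N+](=O)[O-])o1`: 2800 nM
- compound 2 `O=C(NC1(c2ccccc2)CC1)c1ccc([N+](=O)[O-])o1`: 46000 nM
- compound 3 `CN(C)c1ccc(C(C)(C)NC(=O)c2ccc([N+](=O)[O-])o2)cc1`: 79000 nM

All three share one core, a nitrofuran carboxamide, and differ only in the group attached to the amide nitrogen. They were tested in an ADME assay on Vero cells (Chlorocebus sabaeus) for cytotoxicity, read by MTT assay, with a stated time of 48 h; on this read-out higher numbers stand for lower toxicity in this test and lower numbers for higher toxicity in this test. Compound 1 gives 2800 nM, the lowest of the three numbers; compound 2 at 46000 nM and compound 3 at 79000 nM both stand beyond the scatter above it, so compound 1 is the most toxic of the three in this assay.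

Compound 4 `O=C(NCc1ccc(-c2ccc(Cl)cc2)cc1)c1ccc([N+](=O)[O-])o1` has not yet been measured. It differs from compound 1 in one place: 4-chlorophenyl in place of chloro on an aromatic carbon. Among the measured compounds shown here, no measured pair in this set shows the effect of such a change, so nothing here fixes its direction. The expectation for compound 4 is a step of a 1.8-fold higher number from compound 1 to compound 4 (0.25 log units; within the scatter), that is, a small shift upward or none beyond the scatter. Compound 4 is therefore estimated at 5000 nM, with a likely range from 1500 nM to 20000 nM.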

Compound 4, half-maximal cytotoxic concentration: 4400 nM
Beside the measured number, compound 4's estimate is 1.1-fold (0.06 log units) above it, and the stated range covers the measured number.
By their numbers in this assay, from the lowest: compounds 1 and 4 (each within the scatter of the next); then compounds 2 and 3 (each within the scatter of the next).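

In this assay, putting 4-chlorophenyl in place of chloro gives a 1.6-fold higher number from compound 1 to compound 4 (0.20 log units; within the scatter). Among the compounds shown here, this is the first measured change at this position on the six-membered aromatic ring, and it shows that a group with a whole extra aromatic ring can stand there without a step beyond the scatter. For this one pair, then, the size of the group at this position does not separate the two compounds in this test, and nothing measured here offers an explanation.

Still open, going by these compounds, is whether a group of a different kind in the same place, such as a carboxylic acid or a longer carbon chain, would also stay within the scatter of compound 1. A single pair also cannot show whether the same swap would behave this way with a different group on the amide nitrogen.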